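This account rests on a few compounds, and the source may have more. Where it says the series, first, only, none or still open, it means among the compounds named here.

Measured in a functional assay on DU-145 cells (Homo sapiens) for inhibition, read by sulforhodamine B assay, with a stated time of 48 h; a lower number here means a stronger inhibitor of growth, a higher number a weaker inhibitor of growth: compound 1 `COc1cc2cc(Oc3ccc(NC(=O)Nc4cccc(C(F)(F)F)c4)cc3)c(C)nc2cc1OC` gives 2780 nM; compound 2 `COc1cc2cc(Oc3ccc(NC(=O)Nc4ccc(Cl)c(C(F)(F)F)c4)cc3)c(C)nc2cc1OC` gives 1240 nM.

Compound 2 stands lowest of the two, compound 1 sitting higher by a 2.2-fold lower number from compound 1 to compound 2 (0.35 log units; beyond the scatter). Compound 3 `COc1cc2cc(Oc3ccc(NC(=O)Nc4ccc(Cl)c(Cl)c4)cc3)c(C)nc2cc1OC` is compound 2 with chloro in place of trifluoromethyl on an aromatic carbon. Going by the values given here, no measured step swaps trifluoromethyl for chloro; the only step available, from compound 1 to compound 2, concerns the added chloro and is modest. For compound 3 in this assay the expected step is therefore small, a 1.2-fold higher number from compound 2 to compound 3 (0.08 log units; within the scatter), not clearly beyond the scatter in either direction. Compound 3 is estimated at 1500 nM, range 600 nM to 4000 nM.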

Compound 3, concentration for 50% growth inhibition: 4270 nM
Estimate against measurement, compound 3: 2.8-fold (0.45 log units) below; measured number outside the range, above it.
By their numbers in this assay, from the lowest: compound 2; then compounds 1 and 3 (each within the scatter of the next).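

In this assay, chloro does not stand in evenly for trifluoromethyl at this position, ortho to a chloro group: the change gives a 3.4-fold higher number from compound 2 to compound 3 (0.54 log units; beyond the scatter) and takes away the advantage of compound 2. The 3,4-dichlorophenyl group does not separate from the 3-(trifluoromethyl)phenyl group, with a 1.5-fold higher number from compound 1 to compound 3 (0.19 log units; within the scatter) leaving compound 2 alone apart among the three. Nothing available accounts for this step.

Still open, on these data alone, is how a methyl, a methoxy or a nitrile at this position would compare with trifluoromethyl and chloro.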